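The source may report more compounds than this note shows. Statements on the series, on what has been measured and on what is new or still open speak of the compounds shown alone.

Measured so far:
- compound 1, `Cc1cc(-c2nc3ccccc3s2)ccc1N`: > 100000 nM
- compound 2, `Oc1ccc(-c2nc3ccccc3s2)cc1O`: 15600 nM
- compound 3, `COc1ccc(-c2nc3cc(F)ccc3s2)cc1F`: 20600 nM

Three compounds share one core and differ in the groups carried on the outer rings. In a functional assay on KM12 cells (Homo sapiens) for antiproliferative activity (on this read-out higher numbers stand for weaker inhibition of growth and lower numbers for stronger inhibition of growth), compound 1 gives > 100000 nM, which is a limit of the assay and not a number. Compound 2 gives 15600 nM in this assay. Compound 3 gives 20600 nM in this assay; this is the higher of the two numbers, but it sits within the usual scatter of compound 2, so the two cannot be told apart.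

The next compound, compound 4, `COc1ccc(-c2nc3cc(F)ccc3s2)cc1O`, has not been measured. For the measured compounds named here, it differs from compound 3 in one place: hydroxy in place of fluoro on an aromatic carbon No measured pair shows this exact change, so there is no step to lean on. The expected step in this assay is a 1.7-fold lower number from compound 3 to compound 4 (0.23 log units; within the scatter), small and, if anything, toward stronger growth inhibition. Compound 4 is estimated to give about 12000 nM in this assay, with the likely range running from 3000 nM to 50000 nM.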

Compound 4, concentration for 50% growth inhibition: 18400 nM
Estimate against measurement, compound 4: 1.5-fold (0.19 log units) below; the range from low to high includes it.
By their numbers in this assay, from the lowest: compounds 2, 4 and 3 (each within the scatter of the next). At a limit, above all of these: compound 1.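

For the compounds shown here, this is the first pair of compounds that differ in one place, and in this assay it gives a 1.1-fold lower number from compound 3 to compound 4 (0.05 log units; within the scatter) when hydroxy takes the place of fluoro on an aromatic carbon ortho to a methoxy group. At this position, fluoro and hydroxy therefore cannot be told apart in this assay, even though the hydroxy brings a hydrogen-bond donor and the fluoro brings none. Neither compound 3 nor compound 4 sits at a limit, so the step can be read as it stands: the limit of > 100000 nM in this assay, at which 1 of the 4 values shown sits.

As far as these compounds go, what other groups would do at this position remains open, for example an amine, a carboxylic acid or a longer chain such as ethoxy. The compounds shown also leave open whether the same swap would give so small a step on a core without the second fluoro.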